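Thiosemicarbazone series: fluoro to methyl on the aryl ring

A few compounds are considered here, and "the series" means these few. Any claim that something is new, unique, unknown or untested is made for them only; others in the source may bear on it.

Measured so far, all in a functional assay on SGC-7901 cells (Homo sapiens) for antiproliferative activity, read by sulforhodamine B assay, with a stated time of 72 h; a lower number here means a stronger inhibitor, a higher number a weaker inhibitor:
- Compound 1 `Fc1ccccc1NC(=S)N/N=C/c1ccc2ccccc2n1`: reported only as a limit, > 100000 nM.
- Compound 2 `NC(=S)N/N=C/c1cc2ccccc2s1`: reported only as a limit, > 100000 nM.
- Compound 3 `NC(=S)N/N=C/c1nc2ccccc2s1`: reported only as a limit, > 100000 nM.

Compound 1 therefore stands nowhere in particular among the numbers shown: its value is a limit, not a measured number, and the same holds for compound 2 and compound 3. Going by the values given here, all three sit at the limit of > 100000 nM in this assay, at which 3 of the 3 values shown sit, so no step between measured compounds can be read, and no order among them can be stated.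

The next compound, compound 4 `Cc1ccccc1NC(=S)N/N=C/c1ccc2ccccc2n1`, differs from compound 1 in one place: methyl in place of fluoro on an aromatic carbon. The change keeps the shared core of compound 1 and touches only the substituent on the aryl ring, ortho to a large group, where a single heavy atom is swapped for another single heavy atom.

Among the compounds with values here, with nothing but limits on record, no step of any size in this assay is predicted for the change; compound 4 is expected to fall at the same limit, and the step from compound 1 to compound 4 is estimated as a step that the limit leaves unreadable from compound 1 to compound 4. For compound 4 the expected value is 150000 nM, within 40000 nM to 600000 nM.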

Compound 4, half-maximal inhibitory concentration: > 100000 nM
Compound 4: a limit, no number; the forecaster's own chance of this, stated with the estimate: 80%; the middle value is on the limit's open side.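

In this assay compound 4 gives > 100000 nM as a limit and not a number. Compound 1 also stands only as a limit, so no step can be read from compound 1 to compound 4: the limit of > 100000 nM in this assay, at which 4 of the 4 values shown sit.

The compounds shown leave open whether any change to the shared core gives a measured number in this assay at all.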